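Hydroxyphenyl amides on the pyrazole series: moving the hydroxy

This account rests on a few compounds, and the source may have more. Where it says the series, first, only, none or still open, it means among the compounds named here.

Compound 1 `Cc1noc(C)c1Cn1cc(NC(=O)c2ccccc2)cn1` carries an unsubstituted benzamide on the shared core; in a functional assay on cells for antagonist activity at taste receptor type 2 member 8 (Homo sapiens), read by FLIPR and calcium flux, with a stated time of 100 s (on this read-out higher numbers stand for weaker inhibition and lower numbers for stronger inhibition), compound 1 gives 1700 nM. Compound 2 `Cc1noc(C)c1Cn1cc(NC(=O)c2ccccc2O)cn1` carries a hydroxy on an aromatic carbon of that benzamide; in this assay compound 2 gives 1000 nM. Going by the values given here, the only measured step, a 1.7-fold lower number from compound 1 to compound 2 (0.23 log units; within the scatter), is within the scatter, so the two numbers cannot be ordered, and compound 2 stands simply at one of two values that the assay does not separate.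

Compound 3 `Cc1noc(C)c1Cn1cc(NC(=O)c2ccc(O)cc2)cn1` is not yet measured. It differs from compound 2 by 4-hydroxyphenyl in place of 2-hydroxyphenyl on a carbonyl carbon. Among the compounds with values here, no measured step moves a hydroxy from one aromatic carbon to another; the one step that bears on the hydroxy at all, a 1.7-fold lower number from compound 1 to compound 2 (0.23 log units; within the scatter), shows that adding it left the number within the scatter of compound 1. Nothing here argues for a step beyond the scatter in this assay in either direction, so for compound 3 a step of a 1.2-fold higher number from compound 2 to compound 3 (0.08 log units; within the scatter) is expected. The estimate for compound 3 is 1200 nM, with a range from 500 nM to 3000 nM.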

Compound 3, half-maximal inhibitory concentration: 500 nM
For compound 3 the middle estimate is 2.4-fold (0.38 log units) above the measured one, within the range that was stated.
By their numbers in this assay, from the lowest: compounds 3, 2 and 1 (each within the scatter of the next, the first and the last beyond it).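

Adding a hydroxy to the benzamide now gives a step that can be read in this assay: 4-hydroxyphenyl in place of the unsubstituted phenyl gives a 3.4-fold lower number from compound 1 to compound 3 (0.53 log units; beyond the scatter) and this is the first step in the series beyond the scatter, though a modest one, whereas the same addition as 2-hydroxyphenyl gives a 1.7-fold lower number from compound 1 to compound 2 (0.23 log units; within the scatter) and stays within it. Moving the hydroxy itself gives a 2.0-fold lower number from compound 2 to compound 3 (0.30 log units; within the scatter) so 2-hydroxyphenyl and 4-hydroxyphenyl cannot be ordered on this read-out, and the result supports only the narrower statement that compound 3 separates from compound 1 while compound 2 does not. No evidence on any property of these groups accompanies the numbers, so the result stands without an explanation.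

The compounds shown leave open whether the step from compound 1 to compound 3 depends on the hydroxy itself or would also appear with a methoxy, an amine or a carboxylic acid in its place. They also leave open whether any such group would take the number further beyond the scatter of compound 3 in either direction.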